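The compounds below may be only part of what the source reports. "The series", "measured", "known", "first", "only" and "open" are said of these compounds alone.

The series rests on a shared core, and its members differ only in the chains attached to it. Within the data shown here, compound 1, `CCCCCC(=O)O[C@H]1[C@H](O)[C@H](n2ccc(N)nc2=O)O[C@@H]1CO`, is the one compound with a number in a functional assay on HeLa cells (Homo sapiens) for cytotoxicity, read by cell counting, with a stated time of 48 h; a higher number here means that more compound is needed for the effect, a lower number that less compound is needed: in this assay compound 1 gives 0.05 ug/mL. Compound 2, `CCCCCCCCCCCCCCCCCCCC(=O)OC[C@H]1O[C@@H](n2ccc(N)nc2=O)[C@@H](O)[C@@H]1OC(=O)CCCCCCCCCCCCCCCCCCC`, reaches only a limit of this assay, > 10 ug/mL, and this is a limit rather than a number. Among the measured compounds shown here, no pair of measured compounds differs in a single place, so no measured step exists, and the only further entry is the limit of > 10 ug/mL in this assay, at which 1 of the 2 values shown sits. For the measured compounds named here, compound 1 therefore stands as the single measured number, with one limit beside it. Compound 3, `CCCCCCCCCCC(=O)O[C@H]1[C@H](O)[C@H](n2ccc(N)nc2=O)O[C@@H]1CO`, has not yet been measured in this assay. It differs from compound 1 by pentyl in place of hydrogen on a saturated chain carbon, five bonds along the chain from a carbonyl carbon. Going by the values given here, with no measured step to lean on, the step from compound 1 to compound 3 is expected to be small, if anything toward more compound being needed, and is estimated as a 2.0-fold higher number from compound 1 to compound 3 (0.30 log units; within the scatter). Compound 3 is expected to give 0.1 ug/mL in this assay, within an estimated range of 0.02 ug/mL to 0.6 ug/mL.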

Compound 3, concentration for half-maximal effect: 0.04 ug/mL
Compound 3: middle estimate off by 2.5-fold (0.40 log units), on the high side; low and high end bracket the measured number.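

At this place, on a saturated chain carbon, five bonds along the chain from a carbonyl carbon, the series now has its first measured step: in this assay, pentyl in place of hydrogen gives a 1.3-fold lower number from compound 1 to compound 3 (0.10 log units; within the scatter), so the two compounds cannot be told apart. The number in this assay therefore does not respond to this extension of the chain by more than the scatter, which the single limit in the series could not show. Nothing measured here bears on a cause for this.

Among these compounds, compound 2 carries a limit and not a number, and it differs from compound 1 in more than one place, so it yields no step and the other steps to it cannot be read: the limit of > 10 ug/mL in this assay, at which 1 of the 3 values shown sits. Open, going by these compounds, is whether a still longer chain at this same place, or a chain ending in an amine or a carboxylic acid, would leave the number in this assay within the scatter of compound 3 or move it clearly.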